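The source may hold more compounds than are shown below. What is called first, only, known or untested is meant among the compounds shown, and "the series" means these compounds.

Working notes on the urea series sharing the core of compound 1.

For the measured compounds named here, compound 1 `Cc1ccc(F)c(NC(=O)Nc2ccc(Nc3ncnc4c3OCCN4)cc2)c1` is the only member of the set with a numerical result: in an assay on isolated protein for inhibition of proto-oncogene tyrosine-protein kinase receptor Ret variant V804L (Homo sapiens), read by 33P incorporation, with stated times of 15 min and 40 min (a lower number here means a stronger inhibitor, a higher number a weaker inhibitor), compound 1 gives 7000 nM. Compound 2 `O=C(Nc1ccc(Nc2ncnc3c2OCCN3)cc1)Nc1cccc(-c2ccccc2)c1` carries a biphenyl group on the urea nitrogen and in this assay compound 2 returns only a limit, > 10000 nM, not a number. So of the two results shown, one sits at the limit of > 10000 nM in this assay, at which 1 of the 2 values shown sits, and compound 1 stands alone as the single measured value, already in the weak range.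

Compound 3 `O=C(Nc1ccc(Nc2ncnc3c2OCCN3)cc1)Nc1cccs1` is not yet measured. It differs from compound 1 in one place: thiophen-2-yl in place of 2-fluoro-5-methylphenyl on an amide-type nitrogen. Going by the values given here, no measured pair in this set isolates a change of this kind, so there is no step to lean on, and the two values shown only say that compound 1 is weak and compound 2 reaches the limit.

The change from compound 1 to compound 3 is expected to stay within the scatter, as a 1.1-fold higher number from compound 1 to compound 3 (0.06 log units; within the scatter). Compound 3 is therefore estimated at 8000 nM in this assay, with a range from 2500 nM to 25000 nM, and a fair chance that only a limit is reported.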

Compound 3, half-maximal inhibitory concentration: > 10000 nM
Compound 3: only a limit was reported (the forecaster's own chance of this, stated with the estimate: 40%); middle value at least 1.2-fold (0.09 log units) away from the limit.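

In this assay compound 3 gives > 10000 nM, which is a limit and not a number. On the amide-type nitrogen, thiophen-2-yl in place of 2-fluoro-5-methylphenyl gives an at least 1.4-fold higher number from compound 1 to compound 3 (0.15 log units; that floor lies within the scatter); this figure is only a floor, so the result shows no gain in strength from the change, while its true size remains unread. For the compounds shown here, the 2-fluoro-5-methylphenyl group of compound 1 is now the only group on this nitrogen that returns a numerical result, and the rest of the set stops at the limit: the limit of > 10000 nM in this assay, at which 2 of the 3 values shown sit.

The compounds shown leave open whether thiophen-2-yl truly weakens compound 3 relative to compound 1 or leaves it close to the same level, and a more sensitive reading beyond the limit would be needed to separate the two cases. They also leave open what a phenyl ring carrying a trifluoromethyl group, a cyclohexyl ring or a short alkyl chain would give on this nitrogen, and whether any such group would bring a result well below the weak range occupied by compound 1.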